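Chloro for Trifluoromethyl on the Urea Aryl Ring

The source may report more compounds than this note shows. Statements on the series, on what has been measured and on what is new or still open speak of the compounds shown alone.

Among the compounds with values here, compound 2, `COc1cc(Cl)cc(-c2nn(-c3cccc(NC(=O)Nc4ccc(Cl)c(C(F)(F)F)c4)c3)cc2-c2ccncc2)c1`, stands lowest of the two numbers known so far: in a functional assay on UACC-257 cells (Homo sapiens) for inhibition, read by sulforhodamine B assay, with a stated time of 48 h, tested at 0.1 uM (a lower number here means a stronger effect, a higher number a weaker effect of the compound at the concentration tested), compound 2 gives 59%. Within the data shown here, its only neighbour is compound 1, `O=C(Nc1cccc(-n2cc(-c3ccncc3)c(-c3cc(O)cc(Cl)c3)n2)c1)Nc1ccc(Cl)c(Cl)c1`, which in this assay gives 91%, a gap beyond the scatter. Compound 3, `COc1cc(Cl)cc(-c2nn(-c3cccc(NC(=O)Nc4ccc(Cl)c(Cl)c4)c3)cc2-c2ccncc2)c1`, has not yet been measured. It differs from compound 2 in one place: chloro in place of trifluoromethyl on an aromatic carbon. Among the measured compounds shown here, compound 1 carries the same 3,4-dichlorophenyl group but differs from compound 3 elsewhere, so no single step is isolated. A modest move toward a weaker effect is expected, a number 11 percentage points higher from compound 2 to compound 3 (beyond the scatter), near the scatter. Compound 3 is estimated at 70%, between 45% and 95%.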

Compound 3, a percentage reported as activity, at one concentration (the size of the read-out at that concentration, not a potency): 96%
Beside the measured number, compound 3's estimate is 26 percentage points below it; measured number outside the range, above it.
By their numbers in this assay, from the lowest: compound 2; then compounds 1 and 3 (each within the scatter of the next).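

In this assay, within the data shown here, the group on this aromatic carbon matters: with the rest of the molecule held fixed, chloro in place of trifluoromethyl gives a number 37 percentage points higher from compound 2 to compound 3 (beyond the scatter) as the first single-place step at this position. With the 3,4-dichlorophenyl group in place, methyl in place of hydrogen on the oxygen gives only a number 5 percentage points higher from compound 1 to compound 3 (within the scatter) and so shows no change beyond the scatter. No evidence on hand explains the size of the step at the urea aryl ring. As far as these compounds go, how a bromo or nitrile group on that carbon would read remains open. So does the effect of an ethyl group or an amine at the oxygen site.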